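A few compounds are considered here, and "the series" means these few. Any claim that something is new, unique, unknown or untested is made for them only; others in the source may bear on it.

Three compounds have been measured in an assay on isolated protein for binding affinity to Type-2 angiotensin II receptor (Homo sapiens); on this read-out lower numbers stand for stronger inhibition and higher numbers for weaker inhibition:

compound 1 `CCCc1nc(CC)c(C(=O)OCCCOCc2ccccc2)n1Cc1ccc(-c2ccccc2S(=O)(=O)NC(=O)OCCC(C)C)cc1F`: 2 nM
compound 2 `CCCc1nc(CC)c(C(=O)OCc2ccc(C(=O)c3ccccc3)cc2)n1Cc1ccc(-c2ccccc2-c2nn[nH]n2)cc1`: 2000 nM
compound 3 `CCCc1nc(CC)c(C(=O)OCc2ccccc2C(=O)c2ccccc2)n1Cc1ccc(-c2ccccc2S(=O)(=O)NC(=O)OCCc2ccccc2)cc1F`: 0.69 nM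

Compound 1 stands second highest of these three numbers. Compound 3 gives a number below it, a gap beyond the usual scatter, while compound 2 gives a number far above it, also beyond the scatter. Compound 4 `CCCc1nc(CC)c(C(=O)OCc2ccccc2OCCC(C)C)n1Cc1ccc(-c2ccccc2S(=O)(=O)NC(=O)OCCC(C)C)cc1F` is yet to be measured. It differs from compound 1 in one place: 2-(isopentyloxy)phenyl in place of 2-(benzyloxy)ethyl on a saturated chain carbon bound to an oxygen next to a carbonyl group. Within the data shown here, no pair of measured compounds shows this change, so its size is unknown. Given that compound 3, which also carries a ring-bearing ester, gives 0.69 nM, the step of a 1.3-fold lower number from compound 1 to compound 4 (0.12 log units; within the scatter) is expected to be small, perhaps toward a slightly lower number or none beyond the scatter. Compound 4 is estimated at 1.5 nM, in the range 0.4 nM to 6 nM.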

Compound 4, half-maximal inhibitory concentration: 10 nM
The estimate for compound 4 lay 6.7-fold (0.82 log units) below the measured number, outside the stated range (above it).
By their numbers in this assay, from the lowest: compound 3; then compound 1; then compound 4; then compound 2.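

In this assay, among these compounds, 2-(isopentyloxy)phenyl in place of 2-(benzyloxy)ethyl on a saturated chain carbon bound to an oxygen next to a carbonyl group gives a 5.0-fold higher number from compound 1 to compound 4 (0.70 log units; beyond the scatter) and thereby shows, as no earlier pair could, that the number responds to the group held at this place. The step is modest, and both groups carry one aromatic ring and one oxygen. Nothing measured here accounts for the step. The compounds shown leave open how a carboxylic acid or an amine-bearing chain at this place would read, and whether this step would persist on a different core.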